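Shifting the Hydroxyl on the Ester Aryl Ring

The compounds below may be only part of what the source reports. "The series", "measured", "known", "first", "only" and "open" are said of these compounds alone.

Compound 2 `COc1ccc(C2CC(=NOC(=O)c3ccccc3O)CC(c3ccc(OC)cc3)N2C)cc1` gives 29000 nM in a functional assay, with a stated time of 30 min (on this read-out lower numbers stand for stronger inhibition and higher numbers for weaker inhibition), the lowest of the two numbers shown; compound 1 `COc1ccc(C2CC(=NOC(=O)c3ccc(Br)cc3)CC(c3ccc(OC)cc3)N2C)cc1` gives 121000 nM, and the step of a 4.2-fold lower number from compound 1 to compound 2 (0.62 log units; beyond the scatter) separates them. Compound 3 `COc1ccc(C2CC(=NOC(=O)c3cccc(O)c3)CC(c3ccc(OC)cc3)N2C)cc1` differs from compound 2 by 3-hydroxyphenyl in place of 2-hydroxyphenyl on a carbonyl carbon. For the measured compounds named here, no measured step moves a hydroxyl within that ring; the only known step swaps a 4-bromophenyl for a 2-hydroxyphenyl, so it bears on this change only loosely. Compound 3 is therefore expected to sit close by, with a 1.4-fold higher number from compound 2 to compound 3 (0.14 log units; within the scatter) as the expected step. The estimate for compound 3 is 40000 nM, within 12000 nM to 130000 nM.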

Compound 3, half-maximal inhibitory concentration: 34000 nM
The estimate for compound 3 lay 1.2-fold (0.07 log units) above the measured number; measured number inside the range.
By their numbers in this assay, from the lowest: compounds 2 and 3 (each within the scatter of the next); then compound 1.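

In this assay, 3-hydroxyphenyl and 2-hydroxyphenyl on the carbonyl carbon cannot be told apart, with a 1.2-fold higher number from compound 2 to compound 3 (0.07 log units; within the scatter) on moving the hydroxyl. The difference from the 4-bromophenyl ester is thus not confined to 2-hydroxyphenyl, as a 3.6-fold lower number from compound 1 to compound 3 (0.55 log units; beyond the scatter) on replacing 4-bromophenyl with 3-hydroxyphenyl shows. No evidence on the cause of these numbers is available. The compounds shown leave open how 4-hydroxyphenyl would compare with these two hydroxyphenyl esters. They also leave open whether an amine or a carboxylic acid could take the place of the hydroxyl on this ring.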